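A Nitro Group on the Phenyl Ring of Compound 1

The source may report more compounds than this note shows. Statements on the series, on what has been measured and on what is new or still open speak of the compounds shown alone.

Compound 1, `C/C(=N\NC(=O)/C(C#N)=C/c1ccccc1)c1c(O)c2ccc(O)cc2oc1=O`, gives 15800 nM in a functional assay on HeLa cells (Homo sapiens) for cytotoxicity, read by MTT assay, with a stated time of 24 h; a lower number here means a stronger inhibitor, a higher number a weaker inhibitor.
Compound 2, `C/C(=N\NC(=O)/C(C#N)=C/c1ccc(O)cc1)c1c(O)c2ccc(O)cc2oc1=O`, gives 6020 nM in this assay.
Compound 3, `COc1ccc(/C=C(\C#N)C(=O)N/N=C(\C)c2c(O)c3ccc(O)cc3oc2=O)cc1OC`, gives 13500 nM in this assay.

Compound 1 stands at the highest number of the three, so it is the weakest inhibitor of the set; compound 3 sits within the scatter of it, while compound 2 is clearly lower. The new compound 4, `C/C(=N\NC(=O)/C(C#N)=C/c1cccc([N+](=O)[O-])c1)c1c(O)c2ccc(O)cc2oc1=O`, differs from compound 1 in one place: nitro in place of hydrogen on an aromatic carbon. Cut one bond further out, this reads as phenyl to 3-nitrophenyl.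

For the measured compounds named here, two measured steps touch the same phenyl ring. Adding a hydroxy gave a 2.6-fold lower number from compound 1 to compound 2 (0.42 log units; beyond the scatter), a modest gain. Exchanging phenyl for 3,4-dimethoxyphenyl gave a 1.2-fold lower number from compound 1 to compound 3 (0.07 log units; within the scatter), which is within the scatter. Going by the values given here, no measured step introduces a nitro group, so the closest guide is that substituting this ring has so far moved the number little or only modestly downward. A step near the edge of the scatter is therefore expected, a 1.3-fold lower number from compound 1 to compound 4 (0.12 log units; within the scatter), and compound 4 is estimated at 12000 nM, with a range from 5000 nM to 30000 nM.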

Compound 4, half-maximal inhibitory concentration: 24600 nM
Compound 4: the middle estimate sits 2.1-fold (0.31 log units) below what was measured; low and high end bracket the measured number.
By their numbers in this assay, from the lowest: compound 2; then compounds 3, 1 and 4 (each within the scatter of the next).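

In this assay, placing nitro on the phenyl ring brings no clear change (a 1.6-fold higher number from compound 1 to compound 4 (0.19 log units; within the scatter)), whereas a hydroxy group on the same ring had given a step beyond the scatter. The 3-nitrophenyl and 3,4-dimethoxyphenyl rings also cannot be told apart (a 1.8-fold higher number from compound 3 to compound 4 (0.26 log units; within the scatter)). Only the 4-hydroxyphenyl ring stands clearly apart from the 3-nitrophenyl ring (a 4.1-fold higher number from compound 2 to compound 4 (0.61 log units; beyond the scatter)), so among these four compounds a clearly lower number belongs to compound 2 alone.

Going by these compounds, whether an amine or a carboxylic acid on this ring would give a number like that of compound 2 or like that of compound 1 remains open. Nothing available explains why the hydroxy ring stands apart.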